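The source may report more compounds than this note shows. Statements on the series, on what has been measured and on what is new or still open speak of the compounds shown alone.

In a functional assay on PANC-1 cells (Homo sapiens) for inhibition, read by MTT assay, with a stated time of 24 h, tested at 10 uM (on this read-out higher numbers stand for more inhibition at the one concentration tested (going by the name of the read-out) and lower numbers for less inhibition), compound 1 `CC(C)=CCC/C(C)=C/COc1cc(=O)n(CCCO)c2c1CC(CC=C(C)C)C(C)(C)C2` gives 10.6%, compound 2 `CC(C)=CCC1Cc2c(OC(=O)Nc3ccc(F)c(Cl)c3)cc(=O)n(CCCO)c2CC1(C)C` gives 79.8%, and compound 3 `CC(C)=CCC1Cc2c(OC(=O)Nc3cccc(C(F)(F)F)c3)cc(=O)n(CCCO)c2CC1(C)C` gives 54.3%. Compound 3 therefore stands second highest of the three numbers, below compound 2 and well above compound 1. Two steps are known: a number 69.2 percentage points higher from compound 1 to compound 2 (beyond the scatter), and a number 25.5 percentage points lower from compound 2 to compound 3 (beyond the scatter). Compound 4 `CC(C)=CCC1Cc2c(OC(=O)Nc3ccc(Cl)c(Cl)c3)cc(=O)n(CCCO)c2CC1(C)C` differs from compound 3 in one place: 3,4-dichlorophenyl in place of 3-(trifluoromethyl)phenyl on an amide-type nitrogen. The second step bears on this. The 3-chloro-4-fluorophenyl of compound 2 is the closer match to 3,4-dichlorophenyl, and that step was of modest size. A rise of roughly that size is expected, giving a number 17.7 percentage points higher from compound 3 to compound 4 (beyond the scatter). Compound 4 is thus estimated at 72%, with a range from 50% to 88%.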

Compound 4, a percentage reported as inhibition, at one concentration (the size of the read-out at that concentration, not a potency): 61.4%
Beside the measured number, compound 4's estimate is 10.6 percentage points above it; the range from low to high includes it.
By their numbers in this assay, from the lowest: compound 1; then compounds 3 and 4 (each within the scatter of the next); then compound 2.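

Placing 3,4-dichlorophenyl in place of 3-(trifluoromethyl)phenyl on the amide-type nitrogen gives a number 7.1 percentage points higher from compound 3 to compound 4 (within the scatter) and so these two groups cannot be told apart in this assay. A single halogen counts for more, since chloro in place of fluoro on an aromatic carbon gives a number 18.4 percentage points lower from compound 2 to compound 4 (beyond the scatter) and shows that the 3-chloro-4-fluorophenyl group of compound 2 is not interchangeable with 3,4-dichlorophenyl. The (3,4-dichlorophenyl)carbamoyl group in place of 3,7-dimethylocta-2,6-dien-1-yl on the oxygen gives a number 50.8 percentage points higher from compound 1 to compound 4 (beyond the scatter) and so a second carbamoyl group also far exceeds compound 1.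

Still open, as far as these compounds go, is how a phenyl ring carrying an amine or a carboxylic acid, or a plain alkyl chain in place of the ring, would read on this nitrogen. Nothing available here explains these differences.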